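Halogen placement and chloro replacement in a pyrimidine series

This account rests on a few compounds, and the source may have more. Where it says the series, first, only, none or still open, it means among the compounds named here.

The account starts from compound 1, `COc1ccccc1Oc1c(N)nc(-c2ccc(Br)cc2)nc1Cl`, which in a functional assay on B16 cells (Mus musculus) for cytotoxicity, read by CCK-8 assay, with a stated time of 24 h (a higher number here means a weaker inhibitor, a lower number a stronger inhibitor), gives 4440 nM. Compound 2, `COc1ccccc1Oc1c(N)nc(-c2cccc(I)c2)nc1Cl`, differs from it by one change, (3-iodophenyl in place of 4-bromophenyl on an aromatic carbon), and in this assay compound 2 gives 27600 nM; the step is a 6.2-fold higher number from compound 1 to compound 2 (0.79 log units; beyond the scatter). Compound 3, `COc1ccccc1Oc1c(N)nc(-c2ccc(Br)cc2)nc1OCCO`, keeps the 4-bromophenyl group of compound 1 but carries a different core; how the two cores differ is 2-hydroxyethoxy in place of chloro on an aromatic carbon. In this assay compound 3 gives 11800 nM, and the step is a 2.7-fold higher number from compound 1 to compound 3 (0.42 log units; beyond the scatter).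

Compound 4, `COc1ccccc1Oc1c(N)nc(-c2cccc(I)c2)nc1OCCO`, is not yet measured. It relates to compound 3 as compound 2 relates to compound 1: the change is 3-iodophenyl in place of 4-bromophenyl on an aromatic carbon. The surroundings are not identical, since in compound 3 the aromatic carbon is meta to a 2-hydroxyethoxy group and para to a 2-methoxyphenoxy group, whereas in compound 1 it is meta to a chloro group and para to a group of 9 heavy atoms, so this is the same kind of change rather than the same change. For the measured compounds named here, the expectation for compound 4 in this assay is a step of about a 4.7-fold higher number from compound 3 to compound 4 (0.67 log units; beyond the scatter), resting on the single earlier instance, a 6.2-fold higher number from compound 1 to compound 2 (0.79 log units; beyond the scatter), with wide uncertainty because only one pair shows it. Compound 4 is therefore estimated at 55000 nM, expected to fall between 20000 nM and 150000 nM.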

Compound 4, half-maximal inhibitory concentration: 20300 nM
Compound 4: the middle estimate sits 2.7-fold (0.43 log units) above what was measured; the range from low to high includes it.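

On the core of compound 3, putting 3-iodophenyl in place of 4-bromophenyl gives a 1.7-fold higher number from compound 3 to compound 4 (0.24 log units; within the scatter) in this assay, so the step seen on the core of compound 1 does not carry over at its earlier size: the same change on two cores in this assay, a 6.2-fold higher number (0.79 log units; beyond the scatter) from compound 1 to compound 2 and a 1.7-fold higher number (0.24 log units; within the scatter) from compound 3 to compound 4, 3.6-fold (0.56 log units) apart, beyond the scatter of two such steps. The same holds for 2-hydroxyethoxy in place of chloro, which with 3-iodophenyl present gives a 1.4-fold lower number from compound 2 to compound 4 (0.13 log units; within the scatter), unlike its step with 4-bromophenyl present: the same change on two cores in this assay, a 2.7-fold higher number (0.42 log units; beyond the scatter) from compound 1 to compound 3 and a 1.4-fold lower number (0.13 log units; within the scatter) from compound 2 to compound 4, 3.6-fold (0.56 log units) apart, beyond the scatter of two such steps. Across these four compounds, then, the size of each step differs with what stands at the other place, so neither change can be treated as a fixed increment in this series, but the finding rests on a single pair for each core, neither new step can be read as a real change in either direction, and nothing here gives a reason for the difference.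

The 4-bromophenyl and 3-iodophenyl groups differ in both the halogen and its position on the ring, so the compounds shown leave open which of the two lies behind the step from compound 1 to compound 2. Also open, as far as these compounds go, is whether an amine or a longer chain in place of chloro would follow 2-hydroxyethoxy in this respect.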